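The source may report more compounds than this note shows. Statements on the series, on what has been measured and on what is new or still open speak of the compounds shown alone.

Measured so far:
Compound 1 `Cc1ccccc1NC(=O)Nc1cc(C(C)(C)C)nn1-c1ccccc1` gives 8.6 degrees C in an assay on isolated protein for inhibition of serine/threonine-protein kinase 10 (Homo sapiens), read by thermal shift assay, tested at 10 uM; a lower number here means that the compound stabilises the target less, a higher number that the compound stabilises the target more against heat.
Compound 2 `CC(C)(C)c1cc(NC(=O)Nc2ccc(F)c(F)c2)n(-c2ccccc2)n1` gives 3.4 degrees C in this assay.

Among the compounds with values here, compound 2 stands lowest of the two numbers; the one measured step, a number 5.2 degrees C lower from compound 1 to compound 2 (beyond the scatter), lies beyond the scatter. Compound 3 `CC(C)(C)c1cc(NC(=O)Nc2ccccc2)n(-c2ccccc2)n1` differs from compound 2 by phenyl in place of 3,4-difluorophenyl on an amide-type nitrogen. Within the data shown here, no measured step covers exactly this change. The step from compound 1 to compound 2 bears on it only loosely: it swapped one substituted phenyl for another, whereas here the two fluorines of compound 2 are simply removed and nothing takes their place. Since compound 1, which carries a different substituted phenyl, sits well above compound 2, the unsubstituted phenyl of compound 3 is expected to land somewhere between the two, so a rise of moderate size is expected, a number 2.1 degrees C higher from compound 2 to compound 3 (beyond the scatter). For compound 3 the estimated value in this assay is 5.5 degrees C, with a likely range from 2.5 degrees C to 8.5 degrees C.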

Compound 3, shift of the target's melting temperature: 7.2 degrees C
Estimate against measurement, compound 3: 1.7 degrees C below, and the stated range covers the measured number.
By their numbers in this assay, from the lowest: compound 2; then compound 3; then compound 1.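

Against the plain phenyl on this amide-type nitrogen, the two substituted rings now separate in this assay: phenyl in place of 3,4-difluorophenyl gives a number 3.8 degrees C higher from compound 2 to compound 3 (beyond the scatter) and so accounts for the larger part of the earlier gap. The methyl contributes a smaller part, since hydrogen in place of methyl on an aromatic carbon gives a number 1.4 degrees C lower from compound 1 to compound 3 (beyond the scatter) in the other direction, so among these three compounds the methyl goes with more stabilisation and the two fluorines with less. Nothing available explains why either change acts as it does.

Whether both fluorines are needed for the fall stays open, as a phenyl carrying a single fluorine is not among the compounds shown. Also open, from the compounds shown here alone, is how a larger group than methyl, such as ethyl or methoxy, or an amine would behave on this ring.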